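Swapping the Aryl Halide: Predicting Compound 4

This account rests on a few compounds, and the source may have more. Where it says the series, first, only, none or still open, it means among the compounds named here.

Three compounds share one core and differ only in the substituent on the aryloxy ring. Compound 1 `Cc1ccc(Oc2c(/C=N\OCc3c(Cl)c(-c4ccc(F)cc4)nn3C)c(C)nn2C)cc1` gives in a functional assay on SMMC-7721 cells (Homo sapiens) for inhibition, read by MTT assay, with a stated time of 72 h, tested at 25 uM (on this read-out higher numbers stand for more inhibition at the one concentration tested (going by the name of the read-out) and lower numbers for less inhibition), a value of 80%. Compound 2 `COc1ccc(Oc2c(/C=N\OCc3c(Cl)c(-c4ccc(F)cc4)nn3C)c(C)nn2C)cc1` gives 80% in this assay, and compound 3 `Cc1nn(C)c(Oc2ccc(OC(F)(F)F)cc2)c1/C=N\OCc1c(Cl)c(-c2ccc(F)cc2)nn1C` gives 80%. The step of no change at the digits printed from compound 1 to compound 2 (within the scatter), the step of no change at the digits printed from compound 1 to compound 3 (within the scatter) and the step of no change at the digits printed from compound 2 to compound 3 (within the scatter) all stayed within the scatter, so compound 3 stands level with compound 1 and compound 2 on the numbers shown.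

Compound 4 `Cc1nn(C)c(Oc2ccc(OC(F)(F)F)cc2)c1/C=N\OCc1c(Cl)c(-c2ccc(Cl)cc2)nn1C` is the next candidate. Its difference from compound 3 is chloro in place of fluoro on an aromatic carbon, and this sits on the fluorophenyl ring rather than on the aryloxy ring that the three measured steps probed. Among the measured compounds shown here, no measured step bears directly on a halogen exchange at this position; the only guidance is that every change measured so far, on a different ring, left this assay unchanged within the scatter.

On that basis compound 4 is expected to match compound 3, with the step of no change at the digits printed from compound 3 to compound 4 (within the scatter) estimated to lie within the scatter. Compound 4 is therefore estimated at 80%, in a range from 66% to 92%.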

Compound 4, a percentage reported as inhibition, at one concentration (the size of the read-out at that concentration, not a potency): 80%
Beside the measured number, compound 4's estimate shows no gap at the digits printed, and the stated range covers the measured number.
By their numbers in this assay, from the lowest: compounds 1, 2, 3 and 4 (each within the scatter of the next).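

In this assay, the exchange of the 4-fluorophenyl group for the 4-chlorophenyl group gives no change at the digits printed from compound 3 to compound 4 (within the scatter), and this is the first step shown that falls outside the aryloxy ring. Among these four compounds, then, the lack of a readable change is no longer confined to that ring: it also holds for a halogen on an aromatic carbon of the six-membered ring carrying the fluoro or chloro group, para to a large group, with fluoro and chloro indistinguishable there on this read-out. Nothing available here accounts for why the read-out stays the same across this exchange.

The compounds shown leave open whether an amine, a carboxylic acid or a longer chain in that same place would keep the read-out level with the two halogens, since fluoro and chloro are the only groups shown there. They also leave open whether compound 3 and compound 4 would separate at other concentrations, as a percentage at a single concentration is not a potency.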